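The source may hold more compounds than are shown below. What is called first, only, known or untested is meant among the compounds shown, and "the series" means these compounds.

Compound 3 `CN(C)c1ncnc2c1c(-c1cc3ccccc3o1)cn2[C@@H]1O[C@H](CO)[C@@H](O)[C@H]1O` is the compound whose methoxy analogue, compound 4 `COc1ncnc2c1c(-c1cc3ccccc3o1)cn2[C@@H]1O[C@H](CO)[C@@H](O)[C@H]1O`, awaits measurement. In a functional assay on A549 cells (Homo sapiens), read by MTT assay, with a stated time of 72 h (on this read-out higher numbers stand for weaker inhibition and lower numbers for stronger inhibition), compound 3 gives > 20000 nM, which is a limit of the assay and not a number. Compound 3 therefore sits at the limit of > 20000 nM in this assay, at which 1 of the 3 values shown sits, and its place among the numbers shown cannot be fixed more closely than that. The change to compound 4 is methoxy in place of dimethylamino on an aromatic carbon. Among the compounds with values here, no measured step covers this exchange directly. The two other compounds, compound 1 `COc1ncnc2c1c(-c1ccsc1)cn2[C@@H]1O[C@H](CO)[C@@H](O)[C@H]1O` and compound 2 `C#Cc1cn([C@@H]2O[C@H](CO)[C@@H](O)[C@H]2O)c2ncnc(OC)c12`, both carry the methoxy group that enters in compound 4; in this assay compound 1 gives 5170 nM and compound 2 gives 8160 nM, and the step of a 1.6-fold higher number from compound 1 to compound 2 (0.20 log units; within the scatter) varies only the group on the other aromatic carbon. Those two values show that methoxy compounds of this core can reach measurable numbers, though they carry a different group where compound 3 and compound 4 carry theirs. For compound 4 the estimated step is an at least 1.6-fold lower number from compound 3 to compound 4 (0.22 log units; that floor lies within the scatter), toward a measurable number. Compound 4 is expected to give 12000 nM, within 4000 nM to 40000 nM, with a fair chance that only a limit is again reported.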

Compound 4, half-maximal inhibitory concentration: 17700 nM
Beside the measured number, compound 4's estimate is 1.5-fold (0.17 log units) below it; the measured number falls inside the stated range.
By their numbers in this assay, from the lowest: compounds 1 and 2 (each within the scatter of the next); then compound 4. At a limit, above all of these: compound 3.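

Within the data shown here, with the 1-benzofuran-2-yl group held constant, methoxy in place of dimethylamino gives a measured number in this assay, something the earlier compounds could not show for this group. Compound 3 remains a limit of the assay and not a number: the limit of > 20000 nM in this assay, at which 1 of the 4 values shown sits. The exchange therefore has only a floor, an at least 1.1-fold lower number from compound 3 to compound 4 (0.05 log units; that floor lies within the scatter), while among the methoxy compounds the change of the other group is beyond the scatter, with a 2.2-fold higher number from compound 2 to compound 4 (0.34 log units; beyond the scatter) and a 3.4-fold higher number from compound 1 to compound 4 (0.53 log units; beyond the scatter), so 1-benzofuran-2-yl gives modestly weaker inhibition than ethynyl or thiophen-3-yl.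

The compounds shown leave open how a smaller amine such as methylamino, or a thioether such as methylthio, would read in place of methoxy with 1-benzofuran-2-yl kept. They also leave open whether dimethylamino gives a number alongside thiophen-3-yl or ethynyl.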